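A few compounds are considered here, and "the series" means these few. Any claim that something is new, unique, unknown or untested is made for them only; others in the source may bear on it.

In a physicochemical assay for solubility, at pH 7.4 (a higher number here means a more soluble compound, a lower number a less soluble compound), compound 1 (`NS(=O)(=O)c1ccc(S(=O)(=O)CCO)c(F)c1`) gives 3300 ug/mL and compound 2 (`CC(=O)OCCS(=O)(=O)c1ccc(S(N)(=O)=O)s1`) gives 880 ug/mL as the lower of the two numbers, a gap beyond the scatter. Compound 3 (`COCC(=O)OCCCS(=O)(=O)c1ccc(S(N)(=O)=O)s1`) has (((methoxymethyl)carbonyl)oxy)methyl in place of acetoxy on a saturated chain carbon, two bonds along the chain from a sulfonyl sulfur. Among the compounds with values here, no measured pair shows such a change, so only a small downward step is expected in this assay (a 1.4-fold lower number from compound 2 to compound 3 (0.13 log units; within the scatter)), possibly none beyond the scatter. The estimate for compound 3 is 650 ug/mL (expected range 220 ug/mL to 1800 ug/mL).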

Compound 3, solubility: 970 ug/mL
Estimate against measurement, compound 3: 1.5-fold (0.17 log units) below, and the stated range covers the measured number.
By their numbers in this assay, from the lowest: compounds 2 and 3 (each within the scatter of the next); then compound 1.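

In this assay, (((methoxymethyl)carbonyl)oxy)methyl in place of acetoxy on a saturated chain carbon, two bonds along the chain from a sulfonyl sulfur, gives a 1.1-fold higher number from compound 2 to compound 3 (0.04 log units; within the scatter), so this change leaves the reading within the scatter. Within the data shown here, this is the first step readable at this position, and it shows that this larger group can stand there without a difference beyond the scatter. Nothing at hand bears on the reason for this result.

As far as these compounds go, whether an amine or a carboxylic acid at this position would give a step beyond the scatter remains open. Compound 1 differs from compound 2 and compound 3 in more than one place, so its higher number cannot be assigned to a single change.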